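A few compounds are considered here, and "the series" means these few. Any claim that something is new, unique, unknown or untested is made for them only; others in the source may bear on it.

Measured so far:
compound 1 `ClCc1cccc(Cn2cnc3ncnc(Cl)c32)c1`: 1940 nM
compound 2 `ClCc1ccccc1Cn1cnc2ncnc(Cl)c21`: 1900 nM

In a functional assay on U-251 cells (Homo sapiens) for cytotoxicity, read by sulforhodamine B assay, with a stated time of 48 h (on this read-out lower numbers stand for stronger inhibition of growth and higher numbers for weaker inhibition of growth), compound 2 gives 1900 nM, and compound 1 gives 1940 nM. The gap between the two values is within the scatter, so compound 2 stands level with compound 1 rather than apart from it, and the two numbers do not separate the two compounds.

Compound 3 `ClCc1ccccc1Cn1cnc2nc(Cl)nc(Cl)c21` is not yet measured in this assay. Against compound 2 it carries chloro in place of hydrogen on an aromatic carbon. Going by the values given here, no measured pair shows what this change does in this assay, so the expectation rests on compound 2 alone. The step is expected to be small, within or barely beyond the scatter, in no firm direction. The estimated step amounts to a 1.3-fold lower number from compound 2 to compound 3 (0.10 log units; within the scatter). Compound 3 is expected at 1500 nM, with a range from 500 nM to 4500 nM.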

Compound 3, concentration for 50% growth inhibition: 330 nM
Compound 3: the middle estimate sits 4.5-fold (0.66 log units) above what was measured; the whole stated range lies above it.
By their numbers in this assay, from the lowest: compound 3; then compounds 2 and 1 (each within the scatter of the next).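

In this assay, the aromatic carbon between two ring nitrogen atoms is the first position in the series shown to respond to a change: chloro in place of hydrogen gives a 5.8-fold lower number from compound 2 to compound 3 (0.76 log units; beyond the scatter). Going by these compounds alone, one added heavy atom on this carbon is therefore enough to move the read-out beyond the scatter, which the earlier compounds, lacking any measured step, could not show. Nothing available explains the size or direction of this step.

Chloro is the only group shown at this position, so whether an amine, a methoxy group or fluoro would give a similar step remains open. Also open, on these data alone, is whether chloro at this position would give a step of the same size with the chloromethyl group placed as in compound 1.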